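This account rests on a few compounds, and the source may have more. Where it says the series, first, only, none or still open, it means among the compounds named here.

Compound 1 `O=C(NCc1cn(Cc2ccc(F)cc2)nn1)c1cn(-c2ccccc2)nc1-c1ccc(Cl)cc1` gives 2800 nM in a functional assay on HeLa cells (Homo sapiens) for antiproliferative activity, read by sulforhodamine B assay, with a stated time of 48 h; on this read-out lower numbers stand for stronger inhibition of growth and higher numbers for weaker inhibition of growth.
Compound 2 `COc1ccc(Cn2cc(CNC(=O)c3cn(-c4ccccc4)nc3-c3ccc(Cl)cc3)nn2)cc1` gives 1400 nM in this assay.

Compound 2 and compound 1 lie within the scatter of each other. Within the data shown here, the one measured step reads a 2.0-fold lower number from compound 1 to compound 2 (0.30 log units; within the scatter). Compound 3 `COc1cc(Cn2cc(CNC(=O)c3cn(-c4ccccc4)nc3-c3ccc(Cl)cc3)nn2)cc(OC)c1` is not yet measured. It differs from compound 2 by 3,5-dimethoxyphenyl in place of 4-methoxyphenyl on a saturated chain carbon bound to an aromatic nitrogen. Among the measured compounds shown here, that single step is the only one at this position and it stayed within the scatter; no step exchanges one methoxy pattern for another, so the expected step of no change at the digits printed from compound 2 to compound 3 (within the scatter) is none beyond the scatter. Compound 3 is therefore estimated at 1400 nM, in the range 500 nM to 4000 nM.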

Compound 3, concentration for 50% growth inhibition: 730 nM
Compound 3: middle estimate off by 1.9-fold (0.28 log units), on the high side; measured number inside the range.
By their numbers in this assay, from the lowest: compounds 3, 2 and 1 (each within the scatter of the next, the first and the last beyond it).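

Among these compounds, of the groups on the saturated chain carbon bound to an aromatic nitrogen, 3,5-dimethoxyphenyl is the first to open a gap beyond the scatter in this assay, a modest one, with a 3.8-fold lower number from compound 1 to compound 3 (0.58 log units; beyond the scatter) on replacing 4-fluorophenyl. Against 4-methoxyphenyl the same group gives a 1.9-fold lower number from compound 2 to compound 3 (0.28 log units; within the scatter), so the two methoxy patterns cannot be told apart. Nothing available explains the gap to the fluoro compound.

From the compounds shown here alone, whether an amine or a carboxylic acid on this phenyl ring would fit this trend remains open. So does the effect of a longer chain in place of the benzyl carbon.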